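The source may report more compounds than this note shows. Statements on the series, on what has been measured and on what is new or still open speak of the compounds shown alone.

Compound 1 `CCCCOC(=O)NS(=O)(=O)c1sc(CC(C)C)cc1-c1ccc(CN2C(=O)CN(C)C2=O)cc1` has the highest number of the two compounds measured in an assay on membranes from uterus for displacement of a labelled ligand from Angiotensin type II receptor (Sus scrofa), with a stated time of 1.5 h (on this read-out lower numbers stand for stronger inhibition and higher numbers for weaker inhibition), where compound 1 gives 68.6 nM. Compound 2 `CCCCOC(=O)NS(=O)(=O)c1sc(CC(C)C)cc1-c1ccc(Cn2ncnn2)cc1` gives 16 nM in this assay, a step of a 4.3-fold lower number from compound 1 to compound 2 (0.63 log units; beyond the scatter). Compound 3 `CCCCOC(=O)NS(=O)(=O)c1sc(CC(C)C)cc1-c1ccc(Cn2ccc(C(F)(F)F)n2)cc1` differs from compound 1 by 3-(trifluoromethyl)-1H-pyrazol-1-yl in place of 3-methyl-2,5-dioxoimidazolidin-1-yl on a saturated chain carbon bound to an aromatic carbon. Among the measured compounds shown here, the one comparable step, in which the same leaving group was replaced in compound 2 by another five-membered aromatic ring with 2 hetero atoms, lowered the number beyond the scatter, so a drop of similar size is expected here. Compound 3 is expected to give 20 nM, between 6 nM and 65 nM, a step of a 3.4-fold lower number from compound 1 to compound 3 (0.54 log units; beyond the scatter).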

Compound 3, inhibition constant: 9.5 nM
The estimate for compound 3 lay 2.1-fold (0.32 log units) above the measured number, and the stated range covers the measured number.
By their numbers in this assay, from the lowest: compounds 3 and 2 (each within the scatter of the next); then compound 1.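

Replacing 3-methyl-2,5-dioxoimidazolidin-1-yl with 3-(trifluoromethyl)-1H-pyrazol-1-yl gives a 7.2-fold lower number from compound 1 to compound 3 (0.86 log units; beyond the scatter), so the gain seen with 2H-tetrazol-2-yl is not confined to that one aromatic ring. Exchanging those two aromatic rings gives a 1.7-fold lower number from compound 2 to compound 3 (0.23 log units; within the scatter), so the data do not separate them, although only one carries trifluoromethyl. Nothing measured here explains these results.

Still open, as far as these compounds go, is how a pyrazol-1-yl ring without trifluoromethyl would compare at this position. From the compounds shown here alone, the effect of a carboxylic acid or an amine on the same saturated chain carbon also remains unknown.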